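Swapping a bicyclic alcohol for a piperidine in a TLR8 antagonist

The source may report more compounds than this note shows. Statements on the series, on what has been measured and on what is new or still open speak of the compounds shown alone.

Compound 1 `Cn1nc(-c2ccc(OCC34CCC(O)(CC3)CC4)c(F)c2)c2cnc(N)nc21` and compound 2 `Cc1cc(-c2nn(C)c3nc(N)ncc23)cnc1OCC12CCC(N)(CC1)CC2` share a core and were both measured in an assay on THP-1 cells for antagonist activity at Toll-like receptor 8 (Homo sapiens); a higher number here means a weaker inhibitor, a lower number a stronger inhibitor. Compound 1 gives 75 nM in this assay, the highest of the two numbers. Compound 2 gives 1 nM in this assay, a gap far beyond the scatter, but the two compounds differ in more than one place, so no single change can be credited. Compound 3 `Cn1nc(-c2ccc(OCC3CCNCC3)c(F)c2)c2cnc(N)nc21` is the untested compound. It differs from compound 1 by a group of 6 heavy atoms (5 carbon, 1 nitrogen; one six-membered non-aromatic ring with 1 hetero atom) in place of a group of 9 heavy atoms (8 carbon, 1 oxygen; 2 six-membered non-aromatic rings of carbon only), on a saturated chain carbon bound to an oxygen on an aromatic ring. Within the data shown here, no measured pair shows this exact step. The step from compound 1 to compound 3 is expected to be a 6.3-fold lower number from compound 1 to compound 3 (0.80 log units; beyond the scatter), toward a stronger inhibitor. Compound 3 is estimated at 12 nM, within 3 nM to 50 nM, because compound 2 gives 1 nM in this assay.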

Compound 3, half-maximal inhibitory concentration: 60 nM
For compound 3 the middle estimate is 5.0-fold (0.70 log units) below the measured one; measured number outside the range, above it.
By their numbers in this assay, from the lowest: compound 2; then compounds 3 and 1 (each within the scatter of the next).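

In this assay, putting piperidin-4-yl in place of the two-ring alcohol group, on a saturated chain carbon bound to an oxygen on an aromatic ring, gives a 1.3-fold lower number from compound 1 to compound 3 (0.10 log units; within the scatter) with the rest of the molecule unchanged. This position therefore accepts a single ring containing nitrogen in place of two carbon rings bearing an oxygen, with no change that can be told from the usual variation between repeats, even though the entering group has fewer heavy atoms than the one it replaces.

Compound 2 (1 nM) differs from both compound 1 and compound 3 in more than one place, so what sets its number apart remains unassigned, and the effect of the amine on its two-ring group cannot be separated from that of its other changes. Going by these compounds, it also remains open how this position would respond to a morpholine ring or to a methyl group on the piperidine nitrogen. No measurement shown here offers a reason for the outcome of this swap.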